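The source may report more compounds than this note shows. Statements on the series, on what has been measured and on what is new or still open speak of the compounds shown alone.

Working notes on the series. In a functional assay on UACC-257 cells (Homo sapiens) for inhibition, read by sulforhodamine B assay, with a stated time of 48 h, tested at 10 uM (a lower number here means less inhibition of growth, a higher number more inhibition of growth at the concentration tested), compound 1 `C/C(=N\O)c1ccc(NC(=O)Cn2nc(-c3ccc(Cl)cc3)nc2N)cc1` gives 27.8% and compound 3 `C/C(=N/O)c1ccc(NC(=O)Cn2nc(C(F)(F)F)nc2N)cc1` gives 25.6%. The core shared by compound 1 and compound 3 differs from the core of compound 2 `COc1ccc(-c2nc3sc(-c4ccccc4)cn3n2)cc1`, which gives 28%. Compound 2 lies within the scatter of both other compounds, so the three cannot be ranked in this assay.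

Compound 4 `COc1ccc(-c2nc3sc(-c4ccc(Cl)cc4)cn3n2)cc1` keeps the core of compound 2 and has chloro in place of hydrogen on an aromatic carbon, which turns phenyl to 4-chlorophenyl: chloro in place of hydrogen on an aromatic carbon. Among the measured compounds shown here, no measured pair shows this change, so the data give no direct guide to its size or direction. The expectation is therefore a small upward step that does not go beyond the scatter, starting from compound 2 at 28%. The expected step is a number 3 percentage points higher from compound 2 to compound 4 (within the scatter). Compound 4 is estimated at 31%, with an expected range of 17% to 46%.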

Compound 4, percent growth inhibition at one concentration: 15.4%
The estimate for compound 4 lay 15.6 percentage points above the measured number; the whole stated range lies above it.
By their numbers in this assay, from the lowest: compound 4; then compounds 3, 1 and 2 (each within the scatter of the next).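

In this assay, among the compounds shown here, chloro in place of hydrogen on an aromatic carbon, which turns phenyl to 4-chlorophenyl, gives a number 12.6 percentage points lower from compound 2 to compound 4 (beyond the scatter); this is the only pair that differs in one place, and its step is the only one read beyond the scatter. The position, on a six-membered aromatic ring of carbon only and para to a large group, is therefore not indifferent to substitution: here, adding chloro goes with less inhibition of growth at the concentration tested. Nothing available bears on the reason for this step.

A single pair cannot show whether the drop is particular to chloro or would also follow from another group at this carbon, such as fluoro, methoxy or an amine. On these data alone, whether the same change would have a similar effect on the core shared by compound 1 and compound 3 also remains open.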